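A Carbonyl-Linker Change and Its Expected Outcome

This account rests on a few compounds, and the source may have more. Where it says the series, first, only, none or still open, it means among the compounds named here.

Compound 1 `COc1cc(Cl)cc(-c2nn(-c3cccc(NC(=O)c4ccc(Cl)c(Cl)c4)c3)cc2-c2ccncc2)c1` and compound 2 `COc1cc(Cl)cc(-c2nn(-c3cccc(NC(=O)Nc4cccc(C(F)(F)F)c4)c3)cc2-c2ccncc2)c1` share one core and differ only at a carbonyl carbon. In a functional assay on OVCAR-3 cells (Homo sapiens) for inhibition, read by sulforhodamine B assay, with a stated time of 48 h, tested at 10 uM (a lower number here means a stronger effect, a higher number a weaker effect of the compound at the concentration tested), compound 1 gives 53.4%, while compound 2 gives -0.41%. Among the compounds with values here, compound 2 thus stands lowest of the two numbers, with compound 1 as its only neighbour; the one measured step, a number 53.8 percentage points lower from compound 1 to compound 2 (beyond the scatter), is large and beyond the scatter. Compound 3 `COc1cc(Cl)cc(-c2nn(-c3cccc(NC(=O)c4cccc(C(F)(F)F)c4)c3)cc2-c2ccncc2)c1` has not yet been measured in this assay. It differs from compound 2 in one place: 3-(trifluoromethyl)phenyl in place of (3-(trifluoromethyl)phenyl)amino on a carbonyl carbon. Within the data shown here, only the step from compound 1 to compound 2 bears on this, and that step mixes two changes, the aryl group and the amino linker, so it cannot be split between them. Compound 3 keeps the aryl group of compound 2 but the carbonyl linkage of compound 1, so an upward step beyond the scatter toward compound 1 is expected, though smaller than the whole step already seen. For compound 3 the expected step is a number 35.4 percentage points higher from compound 2 to compound 3 (beyond the scatter). Compound 3 is therefore estimated at 35%, between 5% and 65%.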

Compound 3, a percentage reported as activity, at one concentration (the size of the read-out at that concentration, not a potency): 52.3%
The estimate for compound 3 lay 17.3 percentage points below the measured number; measured number inside the range.
By their numbers in this assay, from the lowest: compound 2; then compounds 3 and 1 (each within the scatter of the next).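

In this assay, the step of a number 52.7 percentage points higher from compound 2 to compound 3 (beyond the scatter) comes with the 3-(trifluoromethyl)phenyl ring kept in both compounds, so the amino nitrogen on the carbonyl carbon alone separates a compound with a large effect from one with a much weaker effect. The aryl exchange on the carbonyl carbon, read by itself as a number 1.1 percentage points lower from compound 1 to compound 3 (within the scatter), stays within the scatter, so the earlier step that mixed two changes can now be split: among these three compounds, nearly all of it goes with the amino linker and none that can be told apart goes with the choice between 3,4-dichlorophenyl and 3-(trifluoromethyl)phenyl. Nothing available explains why the amino nitrogen matters so much at this position.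

The compounds shown pair the amino linker only with 3-(trifluoromethyl)phenyl, so it remains open whether the same step would appear with 3,4-dichlorophenyl on that nitrogen. From the compounds shown here alone, it also remains open how the activity would respond to a methylene group or an oxygen atom in place of the amino nitrogen, or to a methyl group placed on that nitrogen.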